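Replacing bromo with hydrogen in compound 3

A few compounds are considered here, and "the series" means these few. Any claim that something is new, unique, unknown or untested is made for them only; others in the source may bear on it.

The compounds measured so far in a functional assay on HeLa cells (Homo sapiens) for inhibition, read by MTT assay, with a stated time of 72 h (on this read-out lower numbers stand for stronger inhibition and higher numbers for weaker inhibition), are
Compound 1 `COc1ccc(-c2nnc(SCCCN3CCN(c4nc5ccccc5s4)CC3)o2)cc1` gives 165000 nM
Compound 2 `Fc1ccc(-c2nnc(SCCCN3CCN(c4nc5ccccc5s4)CC3)o2)cc1` gives 134000 nM
Compound 3 `Brc1ccc(-c2nnc(SCCCN3CCN(c4nc5ccccc5s4)CC3)o2)cc1` gives 243000 nM

Compound 3 is not truly separated from the other two: a 1.5-fold higher number from compound 1 to compound 3 (0.17 log units; within the scatter) and a 1.8-fold higher number from compound 2 to compound 3 (0.26 log units; within the scatter) are both within the scatter. For the measured compounds named here, compound 4 `c1ccc(-c2nnc(SCCCN3CCN(c4nc5ccccc5s4)CC3)o2)cc1` has hydrogen in place of bromo on an aromatic carbon and is the only one with no group at that place. The closest evidence is small, since a 1.2-fold lower number from compound 1 to compound 2 (0.09 log units; within the scatter) also stays within the scatter. In this assay the expected step is a 1.4-fold lower number from compound 3 to compound 4 (0.14 log units; within the scatter) and it should not exceed the scatter. Compound 4 is estimated at 175000 nM with an expected range of 90000 nM to 320000 nM as its likely span.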

Compound 4, half-maximal inhibitory concentration: 229000 nM
Compound 4: middle estimate off by 1.3-fold (0.12 log units), on the low side, within the range that was stated.
By their numbers in this assay, from the lowest: compounds 2, 1, 4 and 3 (each within the scatter of the next).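

In this assay, having no group at this place on the aromatic ring cannot be told apart from having one: a 1.1-fold lower number from compound 3 to compound 4 (0.03 log units; within the scatter), a 1.7-fold higher number from compound 2 to compound 4 (0.23 log units; within the scatter) and a 1.4-fold higher number from compound 1 to compound 4 (0.14 log units; within the scatter). The earlier compounds shown here all carried a group here, so only now is it clear that bromo, fluoro and methoxy each read the same as plain hydrogen. No other data bear on this result. Still open, on these data alone, is whether any group at this place can shift the number beyond the scatter, for example an amine or a carboxylic acid.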